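Swapping chloro for methyl on a triazole-linked phenyl ring

The source may report more compounds than this note shows. Statements on the series, on what has been measured and on what is new or still open speak of the compounds shown alone.

Of the compounds shown here, three sharing one bicyclic lactam core have been tested in a functional assay on SGC-7901 cells (Homo sapiens) for inhibition, read by MTT assay, with a stated time of 24 h; on this read-out lower numbers stand for stronger inhibition and higher numbers for weaker inhibition. Compound 1 `CC1(C)[C@H]2CC[C@]1(C)N(Cc1cn(-c3ccccc3C#N)nn1)C(=O)C2` gives 260 nM. Compound 2 `CC1(C)[C@H]2CC[C@]1(C)N(Cc1cn(-c3cccc(C#N)c3)nn1)C(=O)C2` gives 250 nM. Compound 3 `CC1(C)[C@H]2CC[C@]1(C)N(Cc1cn(-c3ccccc3Cl)nn1)C(=O)C2` gives 220 nM. These three numbers sit close together: the change from compound 1 to compound 2 is a 1.0-fold lower number from compound 1 to compound 2 (0.02 log units; within the scatter), from compound 1 to compound 3 is a 1.2-fold lower number from compound 1 to compound 3 (0.07 log units; within the scatter), and from compound 2 to compound 3 is a 1.1-fold lower number from compound 2 to compound 3 (0.06 log units; within the scatter). Compound 3 therefore stands among its two companions at a level that the scatter of this assay cannot separate from either.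

The next compound, compound 4 `Cc1ccccc1-n1cc(CN2C(=O)C[C@@H]3CC[C@@]2(C)C3(C)C)nn1`, differs from compound 3 only on the phenyl ring attached to the triazole: methyl in place of chloro on an aromatic carbon. Within the data shown here, the closest precedent is the step from compound 1 to compound 3, where one small group replaced another on that same ring and gave a 1.2-fold lower number from compound 1 to compound 3 (0.07 log units; within the scatter); moving a group around the ring, from compound 1 to compound 2, likewise gave a 1.0-fold lower number from compound 1 to compound 2 (0.02 log units; within the scatter). Since every change to this ring so far has stayed within the scatter, the expected step is a 1.0-fold higher number from compound 3 to compound 4 (0.02 log units; within the scatter), with no direction favoured. Compound 4 is thus estimated at 230 nM, in a range from 120 nM to 450 nM.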

Compound 4, half-maximal inhibitory concentration: 350 nM
The estimate for compound 4 lay 1.5-fold (0.18 log units) below the measured number; low and high end bracket the measured number.
By their numbers in this assay, from the lowest: compounds 3, 2, 1 and 4 (each within the scatter of the next).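

In this assay, methyl on this aromatic carbon, ortho to a large group, gives a 1.6-fold higher number from compound 3 to compound 4 (0.20 log units; within the scatter), so this exchange also stays within the scatter. The two other comparisons, a 1.4-fold higher number from compound 2 to compound 4 (0.15 log units; within the scatter) and a 1.3-fold higher number from compound 1 to compound 4 (0.13 log units; within the scatter), are within the scatter as well, which means that cyano, chloro and methyl on this ring cannot be told apart in this assay, and a plain carbon group fits the flat picture that the first three compounds gave. Nothing available here speaks to what lies behind these closely matched numbers.

What these four compounds cannot show is whether this position tolerates every kind of group, since an amine or a carboxylic acid on the same carbon might or might not stay within the scatter. As far as these compounds go, it also remains open how the phenyl ring with only a hydrogen at this place would compare, and whether methyl on another carbon of the ring would read the same as it does in compound 4.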